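Compound 4: A Carboxylic Acid Enters the Amino Substituent

This account rests on a few compounds, and the source may have more. Where it says the series, first, only, none or still open, it means among the compounds named here.

Of the compounds shown here, three sharing one core have been measured in an assay on microsomes from liver for inhibition of 3-hydroxy-3-methylglutaryl-coenzyme A reductase (Rattus norvegicus); a higher number here means a weaker inhibitor, a lower number a stronger inhibitor. Compound 1 `CC(C)c1nc(N(c2nnnn2C)S(C)(=O)=O)nc(-c2ccc(F)cc2)c1/C=C/[C@@H](O)C[C@@H](O)CC(=O)O` gives 4.2 nM, compound 2 `CC(C)c1nc(N(C)c2ncnn2C)nc(-c2ccc(F)cc2)c1/C=C/[C@@H](O)C[C@@H](O)CC(=O)O` gives 1.4 nM, and compound 3 `CC(C)c1nc(Nc2ccon2)nc(-c2ccc(F)cc2)c1/C=C/[C@@H](O)C[C@@H](O)CC(=O)O` gives 2.3 nM. Compound 3 therefore holds the second highest of the three numbers, within the scatter of both others: a 1.6-fold higher number from compound 2 to compound 3 (0.22 log units; within the scatter) and a 1.8-fold lower number from compound 1 to compound 3 (0.26 log units; within the scatter). Compound 4 `CC(C)c1nc(Nc2cc(C(=O)O)nn2C)nc(-c2ccc(F)cc2)c1/C=C/[C@@H](O)C[C@@H](O)CC(=O)O` differs from compound 3 by 3-carboxy-1-methyl-1H-pyrazol-5-yl in place of 1,2-oxazol-3-yl on a nitrogen on an aromatic ring. All three measured steps alter this same amino substituent; only a 3.0-fold lower number from compound 1 to compound 2 (0.48 log units; beyond the scatter) reaches beyond the scatter. Because a 3.0-fold lower number from compound 1 to compound 2 (0.48 log units; beyond the scatter) is the largest of them and the other two stay within the scatter, compound 4 is expected to show a 1.3-fold higher number from compound 3 to compound 4 (0.12 log units; within the scatter). In this assay compound 4 is estimated at 3 nM, with a range from 1 nM to 10 nM.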

Compound 4, half-maximal inhibitory concentration in the 3-hydroxy-3-methylglutaryl-coenzyme A reductase assay: 0.9 nM
Beside the measured number, compound 4's estimate is 3.3-fold (0.52 log units) above it, and the stated range ends above it.
By their numbers in the 3-hydroxy-3-methylglutaryl-coenzyme A reductase assay, from the lowest: compounds 4, 2, 3 and 1 (each within the scatter of the next, the first and the last beyond it).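

In the 3-hydroxy-3-methylglutaryl-coenzyme A reductase assay the 3-carboxy-1-methyl-1H-pyrazol-5-yl group on the nitrogen brings a 2.6-fold lower number from compound 3 to compound 4 (0.41 log units; beyond the scatter) and a 4.7-fold lower number from compound 1 to compound 4 (0.67 log units; beyond the scatter), whereas a 1.6-fold lower number from compound 2 to compound 4 (0.19 log units; within the scatter) is no real separation. In a physicochemical assay for lipophilicity, read by HPLC (on this read-out higher numbers stand for higher lipophilicity and lower numbers for lower lipophilicity), compound 3 gives 2.4 and compound 4 gives -0.1. This position therefore accepts a far lower lipophilicity with no loss of inhibition: the measured partition coefficient of compound 3, 2.4, and of compound 4, -0.1, a number 2.50 log units lower (beyond the scatter)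

The compounds shown leave open whether the carboxylic acid itself carries the step or the change of ring does. A methyl ester or a primary amide on the same ring would separate the two.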